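Benzimidazolylmethyl sulfonamides: aryl change on the nitrogen

A few compounds are considered here, and "the series" means these few. Any claim that something is new, unique, unknown or untested is made for them only; others in the source may bear on it.

Measured so far:
compound 1 `COc1cc(N(Cc2ccc(Br)cc2)S(=O)(=O)c2ccc(C)cc2)cc(OC)c1OC` 10900 nM
compound 2 `COc1cc(N(Cc2nc3ccccc3[nH]2)S(=O)(=O)c2ccc(C(C)(C)C)cc2)cc(OC)c1OC` 33600 nM
compound 3 `Cc1ccc(S(=O)(=O)N(Cc2nc3ccccc3[nH]2)c2ccc(Cl)cc2)cc1` 38300 nM

All three were run in a functional assay on MCF7 cells (Homo sapiens) for inhibition, read by MTT assay, with a stated time of 48 h; a higher number here means a weaker inhibitor, a lower number a stronger inhibitor. Compound 3 carries the highest number of the three. Against compound 2 the gap is within the scatter, so the two cannot be told apart; against compound 1 the gap lies beyond the scatter, and compound 1 therefore sits at the lower end of this small set. Within the data shown here, no pair among the three differs in only one place, so no single step can be read off.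

Compound 4 `COc1ccc(N(Cc2nc3ccccc3[nH]2)S(=O)(=O)c2ccc(C)cc2)cc1OC` is not yet measured. It differs from compound 3 in one place: 3,4-dimethoxyphenyl in place of 4-chlorophenyl on a sulfonamide nitrogen. Compound 2 already shows that a methoxy-bearing aryl on the sulfonamide nitrogen, with the same benzimidazolylmethyl group, gives a number close to that of compound 3. On that basis no step beyond the scatter is expected from compound 3 to compound 4, with at most a slight drift downward: the expected step is a 1.5-fold lower number from compound 3 to compound 4 (0.19 log units; within the scatter). The estimate for compound 4 in this assay is 25000 nM, with a range from 8000 nM to 70000 nM.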

Compound 4, half-maximal inhibitory concentration: > 50000 nM
Compound 4: no number, only a limit; the forecaster's own chance of this, stated with the estimate: 15%; middle value at least 2.0-fold (0.30 log units) from the limit.
By their numbers in this assay, from the lowest: compound 1; then compounds 2 and 3 (each within the scatter of the next). At a limit, above all of these: compound 4.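

In this assay, among these compounds, this is the first step that changes one place only, the aryl on a sulfonamide nitrogen: 3,4-dimethoxyphenyl in place of 4-chlorophenyl gives an at least 1.3-fold higher number from compound 3 to compound 4 (0.11 log units; that floor lies within the scatter). The reading for compound 4 is a limit of the assay and not a number: the limit of > 50000 nM in this assay, at which 1 of the 4 values shown sits. At this position the change therefore brings no lowering of the number, yet the floor of the step lies within the scatter, so a real rise cannot be claimed from it, and the two added methoxy groups can be said only not to have helped here.

On these data alone, how far the true value of compound 4 lies past its limit stays unknown, and with it the full size of the step. Also open, as far as these compounds go, is whether an aryl carrying an amine or a carboxylic acid on this sulfonamide nitrogen, with the rest of compound 3 unchanged, would give a number that differs from that of compound 3 by more than the scatter.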